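Acetyl to 2-hydroxyethyl in a hydrazone acid series

The compounds below may be only part of what the source reports. "The series", "measured", "known", "first", "only" and "open" are said of these compounds alone.

Compound 3 `CC(=O)c1ccccc1N/N=C1\CCC(C)n2c1ncc(C(=O)O)c2=O` stands at the limit of the assay. In a functional assay on the whole organism for inhibition, with Rattus norvegicus as the target (a lower number here means that less compound is needed, a higher number that more compound is needed for the effect), compound 3 gives > 1000 umol/kg, which is a limit and not a number. Compound 1 `COc1ccccc1N/N=C1\CCC(C)n2c1ncc(C(=O)O)c2=O` gives > 1000 umol/kg, likewise a limit. Compound 2 `CC1CC/C(=N\Nc2ccccc2C(F)(F)F)c2ncc(C(=O)O)c(=O)n21` gives > 1000 umol/kg, also a limit. Hence (the limit of > 1000 umol/kg in this assay, at which 3 of the 3 values shown sit), and the steps a step that the two limits leave unreadable from compound 1 to compound 2, a step that the two limits leave unreadable from compound 1 to compound 3 and a step that the two limits leave unreadable from compound 2 to compound 3 cannot be read in size or direction. Compound 4 `CC1CC/C(=N\Nc2ccccc2CCO)c2ncc(C(=O)O)c(=O)n21` differs from compound 3 by 2-hydroxyethyl in place of acetyl on an aromatic carbon. Among the compounds with values here, no measured step bears on a 2-hydroxyethyl, so the size of a step that the limit leaves unreadable from compound 3 to compound 4 is expected to be unreadable as well, with a limit the most likely outcome. Compound 4 is expected to give 1500 umol/kg in this assay, within 300 umol/kg to 6000 umol/kg.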

Compound 4, dose for 50% inhibition: > 100 umol/kg
Compound 4 ended at the assay's limit (the forecaster's own chance of this, stated with the estimate: 75%); the middle value is on the limit's open side.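

The steps from compound 1, compound 2 and compound 3 to compound 4 cannot be read in size or direction, as all four values are limits. On these data alone, whether methoxy, trifluoromethyl, acetyl or 2-hydroxyethyl differ in effect stays open.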